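Adding a Fluorine to Compound 1: An Expected Step

The compounds below may be only part of what the source reports. "The series", "measured", "known", "first", "only" and "open" are said of these compounds alone.

Compound 1, `O=C(Nc1ccc(Oc2ccnc3[nH]ccc23)cc1)c1ccc(-c2ccc(F)cc2F)cn1` — in a functional assay on PC-3 cells (Homo sapiens) for cytotoxicity, read by MTT assay, with a stated time of 72 h (on this read-out higher numbers stand for weaker inhibition and lower numbers for stronger inhibition), compound 1 gives > 10000 nM, which is a limit of the assay and not a number.
Compound 2, `CCc1ccc(-c2ccc(C(=O)Nc3ccc(Oc4ccnc5[nH]ccc45)cc3)nc2)cc1` — in this assay compound 2 gives > 10000 nM, again a limit of the assay.
Compound 3, `O=C(Nc1ccc(Oc2ccnc3[nH]ccc23)cc1)c1cc(-c2ccccc2)ccn1` — in this assay compound 3 gives 3270 nM.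

Going by the values given here, compound 1 therefore stands at the limit of > 10000 nM in this assay, at which 2 of the 3 values shown sit, so its position among the three is known only as a limit, and the one measured step that starts from it, a step that the two limits leave unreadable from compound 1 to compound 2, cannot be sized. Among the compounds with values here, compound 3 is the only compound with a number, but it differs from compound 1 in more than one place, so no step between them is available.

Compound 4, `O=C(Nc1ccc(Oc2ccnc3[nH]ccc23)c(F)c1)c1ccc(-c2ccc(F)cc2F)cn1`, differs from compound 1 by fluoro in place of hydrogen on an aromatic carbon. Within the data shown here, no measured step bears directly on this change, and the only step from compound 1 is unreadable. The estimate for compound 4 therefore rests on the limit of compound 1 alone: compound 4 is expected to give about 8000 nM in this assay, within a range of 2000 nM to 30000 nM. The step of an at least 1.2-fold lower number from compound 1 to compound 4 (0.09 log units; that floor lies within the scatter) that this estimate implies is expected to be small, with a fair chance that only a limit is reported again.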

Compound 4, half-maximal inhibitory concentration: 4720 nM
Compound 4: middle estimate off by 1.7-fold (0.23 log units), on the high side; the range from low to high includes it.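

Fluoro in place of hydrogen on an aromatic carbon of a six-membered aromatic ring of carbon only, ortho to a large group and meta to a large group, gives an at least 2.1-fold lower number from compound 1 to compound 4 (0.32 log units; beyond the scatter) in this assay and brings a number out of the limit. This is the first step from compound 1 that can be sized, and the first among the compounds shown to touch this ring. Going by these compounds, its true size remains unknown, and the printed figure is only a floor, because compound 1 has a limit and not a number: the limit of > 10000 nM in this assay, at which 2 of the 4 values shown sit.

On these data alone, whether chloro, methyl or methoxy on the same carbon would also give a measurable number remains open. Also open, as far as these compounds go, is whether fluoro at this place would have a similar outcome in compound 2 or compound 3.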